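Aryl Ring Swap on a Shared Core: Estimating Compound 4

The source may report more compounds than this note shows. Statements on the series, on what has been measured and on what is new or still open speak of the compounds shown alone.

Three compounds measured in a functional assay on KB cells (Homo sapiens) for antiproliferative activity, read by sulforhodamine B assay, with a stated time of 3 days; a higher number here means that more compound is needed for the effect, a lower number that less compound is needed:
Compound 1 `CCC1=C(O)c2c(oc(-c3ccc(C(C)C)cc3)cc2=O)C(CC)(CC)C1=O`: 8.13 uM
Compound 2 `CCC1=C(O)c2c(oc(-c3ccc(O)cc3)cc2=O)C(CC)(CC)C1=O`: 20.6 uM
Compound 3 `CCC1=C(O)c2c(oc(-c3ccc(C)c(F)c3)cc2=O)C(CC)(CC)C1=O`: 28.1 uM

Compound 3 gives the highest number of the three: the step of a 3.5-fold higher number from compound 1 to compound 3 (0.54 log units; beyond the scatter) is beyond the scatter, while the step of a 1.4-fold higher number from compound 2 to compound 3 (0.13 log units; within the scatter) is within it, so compound 3 and compound 2 cannot be ordered. Compound 4 `CCC1=C(O)c2c(oc(-c3cc(C)ccc3C)cc2=O)C(CC)(CC)C1=O` differs from compound 3 by 2,5-dimethylphenyl in place of 3-fluoro-4-methylphenyl on an aromatic carbon. Among the compounds with values here, the only guidance comes from the earlier aryl exchanges, a 3.5-fold higher number from compound 1 to compound 3 (0.54 log units; beyond the scatter) and a 2.5-fold higher number from compound 1 to compound 2 (0.40 log units; beyond the scatter), both modest; neither involves the incoming ring, so the direction of the new step is uncertain. A modest step is expected, a 1.6-fold lower number from compound 3 to compound 4 (0.19 log units; within the scatter). Compound 4 is therefore estimated at 18 uM, expected between 7 uM and 45 uM.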

Compound 4, concentration for half-maximal effect: 14.5 uM
Compound 4: the middle estimate sits 1.2-fold (0.09 log units) above what was measured; the range from low to high includes it.
By their numbers in this assay, from the lowest: compounds 1, 4, 2 and 3 (each within the scatter of the next, the first and the last beyond it).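

In this assay, the 2,5-dimethylphenyl ring on this carbon, next to the ring oxygen, falls within the scatter of all three earlier rings: the steps are a 1.9-fold lower number from compound 3 to compound 4 (0.29 log units; within the scatter) and a 1.4-fold lower number from compound 2 to compound 4 (0.15 log units; within the scatter) and also a 1.8-fold higher number from compound 1 to compound 4 (0.25 log units; within the scatter) here. Compound 4 therefore cannot be ordered against any of them, although compound 1 and compound 3 differ beyond the scatter. No measurement at hand explains this result.

Still open, going by these compounds, is whether a ring carrying an amine or a carboxylic acid would leave this narrow band of values.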